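Cytotoxicity notes: from compound 2 to compound 3

This account rests on a few compounds, and the source may have more. Where it says the series, first, only, none or still open, it means among the compounds named here.

Measured in a functional assay on KB cells (Homo sapiens) for cytotoxicity; a higher number here means a weaker inhibitor, a lower number a stronger inhibitor:
- compound 1 `Cn1cc(C#N)c2c(N)ncnc21`: > 100000 nM (a limit)
- compound 2 `Cc1cccc(Cn2cc(C(=N)S)c3c(N)ncnc32)c1`: 30000 nM

Among the compounds with values here, compound 2 holds the only actual number in this small set, 30000 nM in this assay. Within the data shown here, the value for compound 1 is a limit of the assay, and the limit of > 100000 nM in this assay, at which 1 of the 2 values shown sits, is the only other reading available.

The next compound is compound 3 `Cn1cc(C(=N)S)c2c(N)ncnc21`. Relative to compound 2, the change is hydrogen in place of 3-methylphenyl on a saturated chain carbon bound to an aromatic nitrogen.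

Among the measured compounds shown here, no measured step covers this change, so the expectation is tentative. Compound 2 is the reference point at 30000 nM, and a modest weakening is expected. The expected 2.3-fold higher number from compound 2 to compound 3 (0.37 log units; beyond the scatter) may end at the assay limit. Compound 3 is estimated at 70000 nM, with an expected range of 30000 nM to 100000 nM.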

Compound 3, half-maximal inhibitory concentration: 15000 nM
Beside the measured number, compound 3's estimate is 4.7-fold (0.67 log units) above it; measured number outside the range, below it.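

In this assay, hydrogen in place of 3-methylphenyl on a saturated chain carbon bound to an aromatic nitrogen produces no difference beyond the scatter (a 2.0-fold lower number from compound 2 to compound 3 (0.30 log units; within the scatter)), so the two groups are not told apart at this place. The change on an aromatic carbon, a group of 2 heavy atoms replaced by one of 3, does register, and its step lies beyond the scatter (an at least 6.6-fold lower number from compound 1 to compound 3 (0.82 log units; beyond the scatter)). The reading for compound 1 is a limit and not a number, so this step has no exact size: the limit of > 100000 nM in this assay, at which 1 of the 3 values shown sits.

On these data alone, it remains open whether a longer chain or an amine on the saturated chain carbon would shift the reading in this assay. Also open, as far as these compounds go, is how a carboxylic acid would read on the aromatic carbon.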